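Moving the methoxy group: from compound 3 to compound 4

A few compounds are considered here, and "the series" means these few. Any claim that something is new, unique, unknown or untested is made for them only; others in the source may bear on it.

The compounds here share one core and differ only in the aryl group at the end of an unsaturated amide chain. Compound 3 `CCCN(CC[C@H]1CC[C@H](NC(=O)/C=C/c2ccc(OC)cc2)CC1)[C@H]1CCc2nc(N)sc2C1` carries a 4-methoxyphenyl group there; in an assay on brain for displacement of a labelled ligand from D(3) dopamine receptor (Rattus norvegicus) (on this read-out higher numbers stand for weaker inhibition and lower numbers for stronger inhibition), compound 3 gives 6.7 nM, the highest of the three numbers measured. Compound 1 `CCCN(CC[C@H]1CC[C@H](NC(=O)/C=C/c2cccc(Cl)c2)CC1)[C@H]1CCc2nc(N)sc2C1` carries a 3-chlorophenyl group and in this assay compound 1 gives 1.2 nM, while compound 2 `CCCN(CC[C@H]1CC[C@H](NC(=O)/C=C/c2ccccc2Cl)CC1)[C@H]1CCc2nc(N)sc2C1`, with a 2-chlorophenyl group, gives 1.2 nM. The step of no change at the digits printed from compound 1 to compound 2 (within the scatter) shows that shifting the chlorine leaves the number unchanged, whereas a 5.6-fold higher number from compound 1 to compound 3 (0.75 log units; beyond the scatter) and a 5.6-fold higher number from compound 2 to compound 3 (0.75 log units; beyond the scatter) show that the methoxy analogue sits modestly higher.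

Compound 4 `CCCN(CC[C@H]1CC[C@H](NC(=O)/C=C/c2cccc(OC)c2)CC1)[C@H]1CCc2nc(N)sc2C1` is the next step: 3-methoxyphenyl in place of 4-methoxyphenyl on a double-bonded chain carbon bound to a double-bonded chain carbon. Among the measured compounds shown here, no measured step shifts a methoxy group around its ring, so the nearest guide is the chloro pair, where such a shift changed nothing, together with the observation that the 4-methoxyphenyl compound gave the highest number. The expected step of a 1.9-fold lower number from compound 3 to compound 4 (0.28 log units; within the scatter) is therefore small, toward a lower number, and may well fall within the scatter. Compound 4 is estimated at 3.5 nM, with a range from 1.2 nM to 10 nM.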

Compound 4, inhibition constant: 9.3 nM
For compound 4 the middle estimate is 2.7-fold (0.42 log units) below the measured one, and the stated range covers the measured number.
By their numbers in this assay, from the lowest: compounds 1 and 2 (each within the scatter of the next); then compounds 3 and 4 (each within the scatter of the next).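

Moving the methoxy group from the 4-methoxyphenyl to the 3-methoxyphenyl arrangement is now measured directly (a 1.4-fold higher number from compound 3 to compound 4 (0.14 log units; within the scatter)), and in this assay this shift, like the shift of chlorine between compound 1 and compound 2, stays within the scatter. The two methoxy compounds therefore read together, and the separation from the chloro compounds holds for compound 4 as well (a 7.8-fold higher number from compound 2 to compound 4 (0.89 log units; beyond the scatter); a 7.8-fold higher number from compound 1 to compound 4 (0.89 log units; beyond the scatter)), the second of these being a plain swap of chloro for methoxy on an aromatic carbon. Among these four compounds, with none going against it, the choice of chloro or methoxy goes with a step beyond the scatter, while the shifts of one group around the ring shown here do not, and nothing available explains this difference.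

The compounds shown leave open how a 2-methoxyphenyl group would read, which would complete the comparison with the chloro pair. They also leave open whether an ethoxy group, with its longer chain, or an amine on the same ring would read with the chloro compounds or with the methoxy compounds.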